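The source may hold more compounds than are shown below. What is called first, only, known or untested is meant among the compounds shown, and "the series" means these compounds.

Of the compounds shown here, three on a shared core have been measured in a functional assay on HL-60 cells (Homo sapiens) for antiproliferative activity, read by MTT assay, with a stated time of 48 h (a higher number here means a weaker inhibitor, a lower number a stronger inhibitor), so far: compound 1 (`COC/C1=C/C[C@](C)(CCC=C(C)C)/C=C/[C@@H](OC(=O)C=C(C)C)[C@](C)(OC)/C=C/C1=O`) gives 4050 nM while compound 2 (`COC/C1=C/C[C@](C)(CCC=C(C)C)/C=C/[C@@H](OC(=O)C=C(C)C)[C@](C)(O)/C=C/C1=O`) gives 3070 nM and compound 3 (`CC(=O)O[C@]1(C)/C=C/C(=O)/C(CO)=C\C[C@](C)(CCC=C(C)C)/C=C/[C@H]1OC(=O)C=C(C)C`) gives 2370 nM on the same read-out. Compound 2 stands within the scatter of both of the others, so these numbers set no order among them.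

The next compound, compound 4 (`CCN(CC)C/C1=C/C[C@](C)(CCC=C(C)C)/C=C/[C@@H](OC(=O)C=C(C)C)[C@](C)(O)/C=C/C1=O`), comes from compound 2 through one change: diethylamino in place of methoxy on a saturated chain carbon bound to a double-bonded ring carbon. In words, diethylamino stands in place of methoxy on a saturated chain carbon bound to a double-bonded ring carbon.

Among the compounds with values here, only one measured step lies between compounds differing in one place: a 1.3-fold lower number from compound 1 to compound 2 (0.12 log units; within the scatter), with hydrogen in place of methyl on an oxygen on a saturated carbon. That step leaves the methoxy group at the site of the new change untouched, so it bears on the change only indirectly. Within the data shown here, compound 3 differs from compound 2 in more than one place, and no measured compound carries diethylamino. The data therefore give no ground for a step beyond the scatter in this assay, in either direction, though the uncertainty is wide. The expected step is a 1.2-fold lower number from compound 2 to compound 4 (0.09 log units; within the scatter) and this estimate stays within the scatter. For compound 4 the estimated value is 2500 nM with an expected range from 800 nM to 7000 nM as its bounds.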

Compound 4, half-maximal inhibitory concentration: 140 nM
Estimate against measurement, compound 4: 18-fold (1.25 log units) above, outside the stated range (below it).
By their numbers in this assay, from the lowest: compound 4; then compounds 3, 2 and 1 (each within the scatter of the next).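

In this assay, within the data shown here, the change to diethylamino gives a 22-fold lower number from compound 2 to compound 4 (1.34 log units; beyond the scatter) and so marks the saturated chain carbon bound to a double-bonded ring carbon as a place where the group carried can shift the read-out strongly, whereas the only earlier single change, a 1.3-fold lower number from compound 1 to compound 2 (0.12 log units; within the scatter) at another oxygen of the shared core, did not move it beyond the scatter. Methoxy, with 2 heavy atoms, and diethylamino, with 5 heavy atoms, have the same counts of hydrogen-bond donors and acceptors and no net charge, so those counts do not separate them; what differs is the number of heavy atoms and the nitrogen in place of oxygen. No measurement at hand accounts for the size of this step.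

The compounds shown leave open whether the step belongs to diethylamino itself or to amines at this place more widely, as dimethylamino, a piperidine or a primary amine would show, and how a carboxylic acid there would compare. They also leave open whether diethylamino gives a step of this size when the methyl ether of compound 1 or the acetate of compound 3 is present.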